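Flavone-benzothiazole series: trifluoromethyl analogue in the cytotoxicity assay

This account rests on a few compounds, and the source may have more. Where it says the series, first, only, none or still open, it means among the compounds named here.

Measured compounds:
compound 1 `O=c1cc(-c2ccccc2)oc2cc(OCCCCNc3nc4ccc([N+](=O)[O-])cc4s3)cc(O)c12`, 41.4 ug/mL
compound 2 `O=c1cc(-c2ccccc2)oc2cc(OCCCCNc3nc4ccc(F)cc4s3)cc(O)c12`, 33.7 ug/mL

Of the compounds shown here, two have been tested in a functional assay on SK-OV-3 cells (Homo sapiens) for cytotoxicity, read by sulforhodamine B assay, with a stated time of 48 h (on this read-out lower numbers stand for stronger inhibition and higher numbers for weaker inhibition), so far. Compound 1 gives 41.4 ug/mL; compound 2 gives 33.7 ug/mL. For the measured compounds named here, the only step measured between them, fluoro in place of nitro on an aromatic carbon, amounts to a 1.2-fold lower number from compound 1 to compound 2 (0.09 log units; within the scatter). Compound 2 therefore stands together with compound 1 within the scatter of this assay, and neither number can be separated from the other.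

Compound 3 `O=c1cc(-c2ccccc2)oc2cc(OCCCCNc3nc4ccc(C(F)(F)F)cc4s3)cc(O)c12` has not been measured. Relative to compound 2 it carries trifluoromethyl in place of fluoro on an aromatic carbon. Going by the values given here, no measured step touches a trifluoromethyl group, so the only guide is the step from compound 1 to compound 2, which stayed within the scatter at the same aromatic carbon. On that basis no change beyond the scatter is expected in this assay for compound 3, in either direction, and the step is estimated as a 1.1-fold lower number from compound 2 to compound 3 (0.05 log units; within the scatter). The expected value for compound 3 in this assay is 30 ug/mL, with a range from 15 ug/mL to 60 ug/mL.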

Compound 3, half-maximal inhibitory concentration: 37.2 ug/mL
The estimate for compound 3 lay 1.2-fold (0.09 log units) below the measured number, and the stated range covers the measured number.
By their numbers in this assay, from the lowest: compounds 2, 3 and 1 (each within the scatter of the next).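

At this aromatic carbon, part of a fused or bridged system of two rings, trifluoromethyl now stands alongside fluoro and nitro. In this assay, the change from fluoro gives a 1.1-fold higher number from compound 2 to compound 3 (0.04 log units; within the scatter), and the change from nitro gives a 1.1-fold lower number from compound 1 to compound 3 (0.05 log units; within the scatter), so a substituent of 4 heavy atoms in place of 1 heavy atom leaves no separable difference, and the three groups cannot be ranked at this position. Nothing at hand bears on why the read-out stays this flat across the three groups.

Whether any group at this aromatic carbon can move the number beyond the scatter stays open, for example an amine or a carboxylic acid, which would put hydrogen-bond donors where the three groups shown have none. Also open, from the compounds shown here alone, is whether a longer chain between the shared core and the fused system would shift the read-out in this assay, or whether the numbers of this series stay together whatever is changed.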